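The compounds below may be only part of what the source reports. "The series", "measured", "known", "first", "only" and "open" are said of these compounds alone.

Compound 1, `COC(=O)/C=C/c1cccc(N(Cc2ccc(/C=C/c3ccccn3)cc2)C(=O)C2CCCCC2)c1`, is the anchor of this comparison. In an assay on isolated protein with Bile acid receptor (Homo sapiens) as the target (a lower number here means that less compound is needed, a higher number that more compound is needed for the effect), compound 1 gives 309 nM, the lowest of the two numbers shown, though its nearest neighbour is no real distance away: compound 2, `COC(=O)/C=C/c1cccc(N(Cc2ccc(/C=C/c3ccccn3)cc2)C(=O)C(C)C)c1`, gives 310 nM in this assay, and the step of a 1.0-fold higher number from compound 1 to compound 2 (0.00 log units; within the scatter) leaves the two indistinguishable. Compound 3, `COC(=O)/C=C/c1cccc(NC(=O)C2CCCCC2)c1`, lacks the whole benzyl arm on the amide nitrogen. In this assay compound 3 reaches only the limit > 1000 nM, so a number is not known for it. This is the point (the limit of > 1000 nM in this assay, at which 1 of the 3 values shown sits).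

The compound to be measured is compound 4, `COC(=O)/C=C/c1cccc(N(Cc2ccc(/C=C/C(=O)OCc3ccccc3)cc2)C(=O)C2CCCCC2)c1`. It differs from compound 1 as follows: benzyloxycarbonyl in place of pyridin-2-yl on a double-bonded chain carbon bound to a double-bonded chain carbon. For the measured compounds named here, no measured step touches this place; the one step on record, from cyclohexyl to isopropyl on the carbonyl carbon, sits elsewhere and was flat. What is known is that the benzyl arm as a whole matters, since compound 3 without it gives only a limit, but how a change at its far end reads cannot be drawn from these data.

Compound 4 is therefore expected near 500 nM, within 150 nM to 2000 nM, the estimated step of a 1.6-fold higher number from compound 1 to compound 4 (0.21 log units; within the scatter) reflecting uncertainty rather than a foreseen direction.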

Compound 4, half-maximal effective concentration: > 1000 nM
Compound 4: no number, only a limit; the forecaster's own chance of this, stated with the estimate: 25%; middle value at least 2.0-fold (0.30 log units) from the limit.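

For the compounds shown here, the far end of the benzyl arm proves sensitive to change: replacing 2-(pyridin-2-yl)ethenyl with 2-(benzyloxycarbonyl)ethenyl gives an at least 3.2-fold higher number from compound 1 to compound 4 (0.51 log units; beyond the scatter), whereas the only earlier single-place step, at the carbonyl carbon, was flat, with a 1.0-fold higher number from compound 1 to compound 2 (0.00 log units; within the scatter). The earlier compounds shown here showed only that the arm as a whole matters, while this result shows that in this assay the group on the double-bonded chain carbon matters as well. Compound 4 gives a limit rather than a number, so only a lower bound on the step is known, and compound 4 joins the compounds held at that limit: the limit of > 1000 nM in this assay, at which 2 of the 4 values shown sit.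

The compounds shown do not separate the loss of pyridin-2-yl from the arrival of benzyloxycarbonyl, since this one change exchanges the ring and also brings in the carbonyl and its oxygens. Going by these compounds, a plain phenyl in place of pyridin-2-yl, or a carboxylic acid at the same place, would help to tell these apart, and it remains open whether the flat step from cyclohexyl to isopropyl would hold with another group at the far end of the arm.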